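Inhibition at a single oral dose across a small series

The source may report more compounds than this note shows. Statements on the series, on what has been measured and on what is new or still open speak of the compounds shown alone.

Compound 1 `N=c1sc(=S)[nH]c2c1cc(-c1ccc(Cl)cc1)n2-c1ccccc1` and compound 2 `Cc1ccc(-c2cc3c(=N)sc(=S)[nH]c3n2-c2ccccc2)cc1` share one core. In a functional assay on the whole organism for inhibition, with Rattus norvegicus as the target, read by ELISA, with stated times of 30 min and 6 h, at a dose of 30 mg/kg by the oral route (on this read-out higher numbers stand for more inhibition at the one dose given (going by the name of the read-out) and lower numbers for less inhibition), compound 1 gives 2%, and compound 2 gives 0%. The change between them is methyl in place of chloro on an aromatic carbon and its step is a number 2 percentage points lower from compound 1 to compound 2 (within the scatter). Compound 3 `CCSc1nc2c(cc(-c3ccc(Cl)cc3)n2-c2ccccc2)c(=N)s1` carries the second core; how it differs from the core of compound 1 is not broken down here. In this assay compound 3 gives 1%, which is within the scatter of compound 1 and of compound 2. Compound 4 `CCSc1nc2c(cc(-c3ccc(C)cc3)n2-c2ccccc2)c(=N)s1` is not yet measured. From compound 3 to compound 4 the change is methyl in place of chloro on an aromatic carbon, the same change as from compound 1 to compound 2, at the same place. That earlier step was a number 2 percentage points lower from compound 1 to compound 2 (within the scatter), and all three measured numbers are near the floor of the read-out, so the step from compound 3 to compound 4 in this assay is expected to be about no change at the digits printed from compound 3 to compound 4 (within the scatter). For compound 4 in this assay the estimate is 1%, with a range from -5% to 8%.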

Compound 4, a percentage reported as inhibition, in the whole organism at one dose (the size of the read-out at that dose, not a potency): 0%
Estimate against measurement, compound 4: 1 percentage points above; measured number inside the range.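

In this assay, the exchange of 4-chlorophenyl for 4-methylphenyl gives a number 1 percentage points lower from compound 3 to compound 4 (within the scatter). Set beside the same exchange on the core of compound 1, the two steps agree: the same change on two cores in this assay, a number 2 percentage points lower (within the scatter) from compound 1 to compound 2 and a number 1 percentage points lower (within the scatter) from compound 3 to compound 4, 1 percentage points apart, within the scatter of two such steps This shows only that the change leaves the number near the floor of the read-out on both cores; it does not show that the step would carry over to a compound with clear inhibition, since a real effect of the change cannot be read so close to the floor.

The compounds shown leave open whether any group at this place can raise inhibition clear of the scatter, for example an amine or a carboxylic acid in place of chloro or methyl, or a longer chain in place of methyl. They also leave open whether the same exchange would give a similar step on a compound that starts well above the floor.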